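Cytotoxicity series: aryl amide variation on a carbonyl carbon

The source may report more compounds than this note shows. Statements on the series, on what has been measured and on what is new or still open speak of the compounds shown alone.

Measured so far:
compound 1 `Cc1cc(S(N)(=O)=O)ccc1NC(=O)COc1ccc(Cl)cc1NC(=O)c1ccccc1C` — 67300 nM
compound 2 `Cc1ccc(C(=O)Nc2cc(Cl)ccc2OCC(=O)Nc2ccc(S(N)(=O)=O)cc2C)cc1` — 54200 nM

In a functional assay on C8166 cells (Homo sapiens) for cytotoxicity, read by MTT assay (a higher number here means that more compound is tolerated, a lower number that less compound is tolerated), compound 1 gives 67300 nM and compound 2 gives 54200 nM. Among the compounds with values here, the one step between them, a 1.2-fold lower number from compound 1 to compound 2 (0.09 log units; within the scatter), shows that moving the methyl on the aryl amide leaves tolerance unchanged. Compound 2 gives the lowest of the two numbers, but its gap to compound 1 is within the scatter, so no order can be read from it.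

Compound 3 `Cc1cc(S(N)(=O)=O)ccc1NC(=O)COc1ccc(Cl)cc1NC(=O)c1cccc(C(F)(F)F)c1` is not yet measured. It differs from compound 2 at the same carbonyl carbon: 3-(trifluoromethyl)phenyl in place of 4-methylphenyl on a carbonyl carbon. Within the data shown here, no measured step involves a trifluoromethyl group, so the only bearing evidence is the flat step from compound 1 to compound 2 at this position. A step of about a 1.2-fold lower number from compound 2 to compound 3 (0.08 log units; within the scatter) is therefore expected, with no movement beyond the scatter. For compound 3 the estimated value is 45000 nM, with a range from 20000 nM to 100000 nM.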

Compound 3, half-maximal cytotoxic concentration: 124000 nM
For compound 3 the middle estimate is 2.8-fold (0.44 log units) below the measured one, outside the stated range (above it).
By their numbers in this assay, from the lowest: compounds 2, 1 and 3 (each within the scatter of the next, the first and the last beyond it).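

In this assay, within the data shown here, the position on the carbonyl carbon no longer looks flat: 3-(trifluoromethyl)phenyl in place of 4-methylphenyl gives a 2.3-fold higher number from compound 2 to compound 3 (0.36 log units; beyond the scatter) and is the only step beyond the scatter, though a modest one. The same group in place of 2-methylphenyl gives a 1.8-fold higher number from compound 1 to compound 3 (0.27 log units; within the scatter) and so stays within the scatter, which means the change stands out only against the 4-methylphenyl compound. No measured information explains this difference between the two steps.

These compounds do not separate the identity of the trifluoromethyl group from its place on the ring, as neither 3-methylphenyl nor 4-(trifluoromethyl)phenyl is among them. Also open, on these data alone, is how tolerance responds to an amine or a carboxylic acid on this aryl ring.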